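Benzyl ether variation on the acylurea series

A few compounds are considered here, and "the series" means these few. Any claim that something is new, unique, unknown or untested is made for them only; others in the source may bear on it.

Compound 3 `Cc1ccc(NC(=O)NC(=O)c2ccc(OCc3ccccc3F)cc2)cc1-c1nc2ccccc2[nH]1` gives 4110 nM in a functional assay on SW-620 cells (Homo sapiens) for inhibition, read by MTT assay, with a stated time of 48 h (on this read-out higher numbers stand for weaker inhibition and lower numbers for stronger inhibition), and holds the lowest number of the three measured compounds. Compound 1 `Cc1ccc(NC(=O)NC(=O)c2ccc(OCc3cccc(Cl)c3)cc2)cc1-c1nc2ccccc2[nH]1` gives 16000 nM in this assay, and compound 2 `Cc1ccc(NC(=O)NC(=O)c2ccc(OCc3ccc(C(F)(F)F)cc3)cc2)cc1-c1nc2ccccc2[nH]1` gives 15300 nM. The step from compound 1 to compound 2 is a 1.0-fold lower number from compound 1 to compound 2 (0.02 log units; within the scatter), so the 3-chlorophenyl and 4-(trifluoromethyl)phenyl variants cannot be separated. Against these, the 2-fluorophenyl variant shows a 3.9-fold lower number from compound 1 to compound 3 (0.59 log units; beyond the scatter) and a 3.7-fold lower number from compound 2 to compound 3 (0.57 log units; beyond the scatter), both beyond the scatter but modest.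

Compound 4 `Cc1ccc(NC(=O)NC(=O)c2ccc(OCc3cccc(Cl)c3Cl)cc2)cc1-c1nc2ccccc2[nH]1` is the next member: 2,3-dichlorophenyl in place of 2-fluorophenyl on a saturated chain carbon bound to an oxygen on an aromatic ring. The 2,3-dichlorophenyl group keeps a substituent where compound 3 carries its fluorine and also carries chlorine where compound 1 does. The steps from compound 1 and compound 2 to compound 3 bear on this change, and both were modest. Compound 1 with its 3-chlorophenyl group gave 16000 nM, so a number between that of compound 1 and that of compound 3 appears most likely, with a modest move towards weaker inhibition. For compound 4 the estimate in this assay is 7500 nM, with a range of 2500 nM to 20000 nM. For compound 4 this means an expected step of a 1.8-fold higher number from compound 3 to compound 4 (0.26 log units; within the scatter).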

Compound 4, half-maximal inhibitory concentration: 42100 nM
Compound 4: middle estimate off by 5.6-fold (0.75 log units), on the low side, outside the stated range (above it).
By their numbers in this assay, from the lowest: compound 3; then compounds 2 and 1 (each within the scatter of the next); then compound 4.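

Adding a chloro group to the 3-chlorophenyl ring gives a 2.6-fold higher number from compound 1 to compound 4 (0.42 log units; beyond the scatter) in this assay, so this second halogen on the ring raises the number further rather than moving it towards that of the 2-fluorophenyl variant. The lower number of compound 3 therefore does not extend to the 2,3-dichlorophenyl group, as shown by a 10-fold higher number from compound 3 to compound 4 (1.01 log units; beyond the scatter), the largest step yet seen at this place on the saturated chain carbon, while a 2.8-fold higher number from compound 2 to compound 4 (0.44 log units; beyond the scatter) also separates the new group from the 4-(trifluoromethyl)phenyl variant and leaves compound 4 as the weakest of the four. No measurement at hand accounts for this rise.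

Still open, from the compounds shown here alone, is whether the lower number of compound 3 belongs to fluorine itself or to the presence of a single substituent on the ring, a question that 2-chlorophenyl and 2,3-difluorophenyl groups could separate. Also open, going by these compounds, is how an unsubstituted phenyl group, or a longer chain in place of the saturated chain carbon, would read against these four compounds.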